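Shorter Amine Chain on a Shared Core: Expected Clearance

The compounds below may be only part of what the source reports. "The series", "measured", "known", "first", "only" and "open" are said of these compounds alone.

Measured so far:
Compound 1 `CCN(CC)CCN(C)c1ccc(Cn2c(=O)[nH]c3c(N)nc(C(F)(F)F)cc32)cn1`: 11 mL.min-1.g-1
Compound 2 `CN1CCN(c2ccc(Cn3c(=O)[nH]c4c(N)nc(C(F)(F)F)cc43)cn2)CC1`: 46 mL.min-1.g-1

Going by the values given here, in an in vitro ADME assay on microsomes from liver (Rattus norvegicus) for pharmacokinetics (a lower number here means slower removal, a higher number faster removal of the compound), compound 1 gives the lower of the two numbers measured; compound 2, its only neighbour, sits at a 4.2-fold higher number from compound 1 to compound 2 (0.62 log units; beyond the scatter). Compound 3 `CN(C)CCNc1ccc(Cn2c(=O)[nH]c3c(N)nc(C(F)(F)F)cc32)cn1` has not yet been measured. It differs from compound 1 in one place: (2-(dimethylamino)ethyl)amino in place of (2-(diethylamino)ethyl)(methyl)amino on an aromatic carbon. Among the compounds with values here, no measured step shows exactly this exchange of one open chain for another on the same aromatic carbon; the only step known replaces the whole chain with a ring, and that one moved the number in this assay upward by a modest amount. Since compound 3 keeps an open chain but loses three carbon atoms and gains a hydrogen-bond donor, its number is expected to stay close to that of compound 1 or drift a little upward, with a 1.6-fold higher number from compound 1 to compound 3 (0.21 log units; within the scatter) as the estimated step. For compound 3 the expected value in this assay is 18 mL.min-1.g-1, within a range from 7 mL.min-1.g-1 to 45 mL.min-1.g-1.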

Compound 3, intrinsic clearance in microsomes: 16 mL.min-1.g-1
For compound 3 the middle estimate is 1.1-fold (0.05 log units) above the measured one; the range from low to high includes it.
By their numbers in this assay, from the lowest: compounds 1 and 3 (each within the scatter of the next); then compound 2.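

In this assay the exchange of one open chain for another on this aromatic carbon, with (2-(dimethylamino)ethyl)amino entering in place of (2-(diethylamino)ethyl)(methyl)amino, stays within the scatter (a 1.5-fold higher number from compound 1 to compound 3 (0.16 log units; within the scatter)). The 4-methylpiperazin-1-yl ring of compound 2 stands apart from the shorter chain as well (a 2.9-fold lower number from compound 2 to compound 3 (0.46 log units; beyond the scatter)), so among these three compounds only the ring gives a number beyond the scatter from the others. No measurement here explains this difference between ring and open chains.

The two chains differ in both size and hydrogen-bond donors, and the compounds shown cannot separate these two features. As far as these compounds go, how a morpholine ring, a piperidine ring or a longer chain ending in a hydroxyl group would behave in this assay on this aromatic carbon also stays open.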